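The compounds below may be only part of what the source reports. "The series", "measured", "known", "first", "only" and "open" are said of these compounds alone.

The shared core is carried by three measured compounds: compound 1 `C=CCOc1ccc2c(=O)c(-c3cc(OC)c(OC)cc3OC)coc2c1`, compound 2 `COc1cccc(C(=O)Oc2ccc3c(=O)c(-c4cc(OC)c(OC)cc4OC)coc3c2)c1` and compound 3 `COc1cc(OC)c(-c2coc3cc(OCc4ccccc4F)ccc3c2=O)cc1OC`. In a functional assay on B16 cells (Mus musculus) for antiproliferative activity, read by MTT assay, with a stated time of 24 h (on this read-out lower numbers stand for stronger inhibition and higher numbers for weaker inhibition), compound 1 gives 5100 nM and compound 3 gives 1610 nM. For compound 2 this assay returns only a limit, > 10000 nM, so its place on the scale is bounded on one side alone (the limit of > 10000 nM in this assay, at which 1 of the 3 values shown sits). The step of a 3.2-fold lower number from compound 1 to compound 3 (0.50 log units; beyond the scatter) is modest, the step of an at least 6.2-fold lower number from compound 2 to compound 3 (0.79 log units; beyond the scatter) is at least modest, while an at least 1.9-fold higher number from compound 1 to compound 2 (0.29 log units; that floor lies within the scatter) stays within the usual spread of repeated measurements.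

Compound 4 `COc1cc(OC)c(-c2coc3cc(OCc4ccccc4C)ccc3c2=O)cc1OC` has not yet been measured. It differs from compound 2 by 2-methylbenzyl in place of (3-methoxyphenyl)carbonyl on an oxygen on an aromatic ring. The step that bears most directly on this change is an at least 6.2-fold lower number from compound 2 to compound 3 (0.79 log units; beyond the scatter), since compound 3 carries a 2-fluorobenzyl group on the same oxygen and sits at 1610 nM; compound 1 with its allyl group at 5100 nM points the same way. A drop beyond the scatter is therefore expected, and compound 4 is estimated at 1800 nM, within 800 nM to 5000 nM. The expected step is an at least 5.5-fold lower number from compound 2 to compound 4 (0.74 log units; beyond the scatter).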

Compound 4, half-maximal inhibitory concentration: 2150 nM
For compound 4 the middle estimate is 1.2-fold (0.08 log units) below the measured one; low and high end bracket the measured number.
By their numbers in this assay, from the lowest: compounds 3 and 4 (each within the scatter of the next); then compound 1. At a limit, above all of these: compound 2.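

With a second substituted benzyl group on the oxygen, the step in this assay is an at least 4.6-fold lower number from compound 2 to compound 4 (0.66 log units; beyond the scatter), so the gain seen with 2-fluorobenzyl is not tied to the fluoro group. Swapping that fluoro for methyl on the aromatic carbon gives a 1.3-fold higher number from compound 3 to compound 4 (0.13 log units; within the scatter), which leaves the two compounds indistinguishable here, and the step from the allyl ether, a 2.4-fold lower number from compound 1 to compound 4 (0.38 log units; beyond the scatter), shows that 2-methylbenzyl, like 2-fluorobenzyl, stands clear of allyl on this oxygen. For the compounds shown here, compound 2 remains the one compound with no number, and its comparisons are bounded on one side only, as it stands at a limit: the limit of > 10000 nM in this assay, at which 1 of the 4 values shown sits.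

The compounds shown do not separate the carbonyl link of compound 2 from its 3-methoxyphenyl ring, which a 3-methoxybenzyl group on the same oxygen would do. They also leave open how plain benzyl, a benzyl ring carrying a carboxylic acid, or a longer chain ending in an amine would fare at this oxygen.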